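The source may report more compounds than this note shows. Statements on the series, on what has been measured and on what is new or still open speak of the compounds shown alone.

Compound 2 `COc1ccc(-c2csc(N3N=C(c4ccc(C)s4)CC3c3ccc(F)cc3)n2)cc1` and compound 3 `COc1ccc(-c2csc(N3N=C(c4ccc(Cl)s4)CC3c3ccc(F)cc3)n2)cc1` share a core that differs only as counted in chloro in place of methyl on an aromatic carbon. In an ADME assay on NIH3T3 cells (Mus musculus) for cytotoxicity, read by XTT assay, with a stated time of 24 h (a lower number here means a stronger inhibitor, a higher number a weaker inhibitor), compound 2 gives 147 ug/mL, and in this assay compound 3 gives 103 ug/mL; the step is a 1.4-fold lower number from compound 2 to compound 3 (0.15 log units; within the scatter). Compound 1 `Cc1ccc(C2=NN(c3nc(-c4ccc([N+](=O)[O-])cc4)cs3)C(c3ccc(F)cc3)C2)s1` carries the change nitro in place of methoxy on an aromatic carbon on the core of compound 2. In this assay compound 1 gives 15.6 ug/mL, so that the step is a 9.4-fold lower number from compound 2 to compound 1 (0.97 log units; beyond the scatter). Compound 4 `O=[N+]([O-])c1ccc(-c2csc(N3N=C(c4ccc(Cl)s4)CC3c3ccc(F)cc3)n2)cc1` carries the same change, (nitro in place of methoxy on an aromatic carbon), on the core of compound 3, the place being described in the same words. For compound 4 the expected step in this assay is an 8.6-fold lower number from compound 3 to compound 4 (0.93 log units; beyond the scatter). Among the measured compounds shown here, that expectation rests on the single earlier instance of this change, a 9.4-fold lower number from compound 2 to compound 1 (0.97 log units; beyond the scatter), seen on one core only. Compound 4 is therefore estimated at 12 ug/mL, with a range from 5 ug/mL to 30 ug/mL.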

Compound 4, half-maximal inhibitory concentration: > 500 ug/mL
Compound 4: no number, only a limit; the forecaster's own chance of this, stated with the estimate: 5%; middle value at least 41-fold (1.61 log units) from the limit.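

In this assay compound 4 gives > 500 ug/mL, a limit of the assay and not a number. Nitro in place of methoxy does not carry from the core of compound 2 to the core of compound 3, where the direction reverses, with an at least 4.8-fold higher number from compound 3 to compound 4 (0.68 log units; beyond the scatter): the same change on two cores in this assay, a 9.4-fold lower number (0.97 log units; beyond the scatter) from compound 2 to compound 1 and an at least 4.8-fold higher number (0.68 log units; beyond the scatter) from compound 3 to compound 4, at least 45-fold (1.66 log units) apart, beyond the scatter of two such steps. Chloro in place of methyl likewise behaves differently once nitro is present, with an at least 32-fold higher number from compound 1 to compound 4 (1.50 log units; beyond the scatter), though one pair of cores and a limit give neither the full size of these gaps nor a cause: the same change on two cores in this assay, a 1.4-fold lower number (0.15 log units; within the scatter) from compound 2 to compound 3 and an at least 32-fold higher number (1.50 log units; beyond the scatter) from compound 1 to compound 4, at least 45-fold (1.66 log units) apart, beyond the scatter of two such steps.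

Still open, from the compounds shown here alone, is whether the reversal holds with a nitrile or an amine in place of nitro. Also open, going by these compounds, is how bromo or ethyl would behave in place of chloro or methyl.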